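Chain lengthening and tolerated concentration on two related cores

The source may hold more compounds than are shown below. What is called first, only, known or untested is meant among the compounds shown, and "the series" means these compounds.

Compound 3 `CCCCCCc1cc2cn(COCCO)c(O)nc-2n1` and compound 1 `CCCCCCCCCCc1cc2cn(COCCO)c(O)nc-2n1` share one core and differ by butyl in place of hydrogen on a saturated chain carbon, six bonds along the chain from an aromatic carbon. In a functional assay on HEL cells (Homo sapiens), read by microscopy (a lower number here means that less compound is tolerated, a higher number that more compound is tolerated), compound 1 gives 80000 nM. For compound 3 this assay reports a limit, > 400000 nM. The step of an at least 5.0-fold lower number from compound 3 to compound 1 (0.69 log units; beyond the scatter) rests on (the limit of > 400000 nM in this assay, at which 1 of the 3 values shown sits), so its true size is open at the upper end.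

Compound 2 `CCCCCC#Cc1cc2cn(COCCO)c(=O)nc2o1` carries a second core, and the difference between the two cores is not broken down here. For compound 2 this assay reports a limit, >= 100000 nM, which is the limit of >= 100000 nM in this assay, at which 1 of the 3 values shown sits.

Compound 4 `CCCCCCCCCC#Cc1cc2cn(COCCO)c(=O)nc2o1` differs from compound 2 by butyl in place of hydrogen on a saturated chain carbon, five bonds along the chain from a triple-bonded carbon. Going by the values given here, this is the same kind of change as the one from compound 3 to compound 1, though the place differs: there it sits six bonds along the chain from an aromatic carbon, here five bonds along the chain from a triple-bonded carbon.

For compound 4 the step of an at least 2.5-fold lower number from compound 2 to compound 4 (0.39 log units; beyond the scatter) is expected, in line with the measured step from compound 3 to compound 1 an at least 5.0-fold lower number from compound 3 to compound 1 (0.69 log units; beyond the scatter). Compound 4 is accordingly estimated at 40000 nM, with a range from 10000 nM to 200000 nM.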

Compound 4, minimum cytotoxic concentration: >= 20000 nM
Compound 4 ended at the assay's limit (the forecaster's own chance of this, stated with the estimate: 30%); the middle value does not contradict the limit.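

Going by these compounds alone, no step from compound 2 to compound 4 can be read: both values in this assay are limits. The compounds shown leave open whether butyl in place of hydrogen on a saturated chain carbon lowers the number on the core of compound 2, as it does from compound 3 to compound 1 on theirs.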